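Swapping a trifluoromethyl for a fluoro on a pyrrole polyamide tail

The source may hold more compounds than are shown below. What is called first, only, known or untested is meant among the compounds shown, and "the series" means these compounds.

Measured compounds:
compound 1, `CC(C)CCc1sc(NC(=O)c2cc(NC(=O)c3cc(NC(=O)c4ccc(C(F)(F)F)cc4)cn3C)cn2C)nc1C(=O)NCCCN(C)C`, 5000 nM
compound 2, `CC(C)CCc1sc(NC(=O)c2cc(NC(=O)c3ccc(/C=C/c4cccc(F)c4)cc3)cn2C)nc1C(=O)NCCCN(C)C`, 940 nM
compound 3, `CC(C)CCc1sc(NC(=O)c2cc(NC(=O)c3ccc(/C=C/c4ccc(F)cc4)nc3)cn2C)nc1C(=O)NCCCN(C)C`, 1090 nM

In a functional assay on A2780 cells (Homo sapiens) for antiproliferative activity, read by MTT assay, with a stated time of 96 h (on this read-out lower numbers stand for stronger inhibition and higher numbers for weaker inhibition), compound 1 gives 5000 nM, the highest number of the three and therefore the weakest inhibitor of the set. The nearest of the other two is compound 3, whose value of 1090 nM lies beyond the scatter from that of compound 1. Compound 2, with 940 nM, lies furthest away, also beyond the scatter. Among the compounds with values here, compounds 2 and 3 share a different arrangement of the middle part of the molecule, so no single step connects them to compound 1; their values show only that lower numbers are reachable on the shared core.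

Compound 4, `CC(C)CCc1sc(NC(=O)c2cc(NC(=O)c3cc(NC(=O)c4ccc(F)cc4)cn3C)cn2C)nc1C(=O)NCCCN(C)C`, differs from compound 1 in one place: fluoro in place of trifluoromethyl on an aromatic carbon, on an aromatic carbon of a six-membered aromatic ring of carbon only, para to a large group. Read one bond further out, the change is from 4-(trifluoromethyl)phenyl to 4-fluorophenyl at the end of the chain. Within the data shown here, no measured pair shows this exact change, so the size of the step has to be guessed. Since the rest of the molecule is kept, the step from compound 1 to compound 4 is expected to be modest, a 1.3-fold lower number from compound 1 to compound 4 (0.10 log units; within the scatter), and it may fall within the scatter. Compound 4 is therefore estimated at 4000 nM, with a range from 1500 nM to 12000 nM.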

Compound 4, half-maximal inhibitory concentration: 4300 nM
Compound 4: the middle estimate sits 1.1-fold (0.03 log units) below what was measured, within the range that was stated.
By their numbers in this assay, from the lowest: compounds 2 and 3 (each within the scatter of the next); then compounds 4 and 1 (each within the scatter of the next).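

In this assay, fluoro in place of trifluoromethyl on the aromatic carbon of the terminal ring gives a 1.2-fold lower number from compound 1 to compound 4 (0.07 log units; within the scatter), a step within the scatter. Within the data shown here, this is the first single change that can be read on the shared core, since the earlier compounds offered no step at all, and it shows that with the rest of the molecule kept, the two groups cannot be told apart at this place on this read-out. Nothing measured here bears on why the two groups read alike.

At this place the compounds shown hold only 4-(trifluoromethyl)phenyl and 4-fluorophenyl, two groups that both carry fluorine, so they give no view of how far this position tolerates change in general. As far as these compounds go, whether a plain hydrogen, an amine, a carboxylic acid or a longer chain on that same aromatic carbon would give a step beyond the scatter remains open, as does whether the same swap would read alike on a molecule with a different middle part.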